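Fluoro for trifluoromethyl on the styryl aromatic ring

The source may report more compounds than this note shows. Statements on the series, on what has been measured and on what is new or still open speak of the compounds shown alone.

Measured so far:
compound 1 `COc1cc(/C=C/c2cc(=O)c3c(OC)cc(OC)cc3o2)cc(OC)c1`: 16700 nM
compound 2 `COc1cc(OC)c2c(=O)cc(/C=C/c3ccc(C(F)(F)F)cc3)oc2c1`: 19000 nM

Two compounds have been run in a functional assay on HeLa cells (Homo sapiens) for antiproliferative activity, read by MTT assay, with a stated time of 12 h; a higher number here means a weaker inhibitor, a lower number a stronger inhibitor. Compound 1 `COc1cc(/C=C/c2cc(=O)c3c(OC)cc(OC)cc3o2)cc(OC)c1` gives 16700 nM; compound 2 `COc1cc(OC)c2c(=O)cc(/C=C/c3ccc(C(F)(F)F)cc3)oc2c1` gives 19000 nM. Compound 2 holds the highest of the two numbers, but its nearest neighbour, compound 1, lies within the scatter of it, so no order between the two can be read; both are weak inhibitors.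

Compound 3 `COc1cc(OC)c2c(=O)cc(/C=C/c3ccc(F)cc3)oc2c1` is the next candidate and has not been measured. It differs from compound 2 in one place: fluoro in place of trifluoromethyl on an aromatic carbon.

Within the data shown here, no measured pair differing in one place is available, so the size of this step cannot be anchored. Since compound 1, with a different aromatic substitution, returns 16700 nM, the aromatic substituent appears to move the number little in this set, and the expected step of a 1.1-fold lower number from compound 2 to compound 3 (0.02 log units; within the scatter) is taken as none beyond the scatter. Compound 3 is expected to give 18000 nM, with a range of 8000 nM to 40000 nM.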

Compound 3, half-maximal inhibitory concentration: 14200 nM
Beside the measured number, compound 3's estimate is 1.3-fold (0.10 log units) above it; low and high end bracket the measured number.
By their numbers in this assay, from the lowest: compounds 3, 1 and 2 (each within the scatter of the next).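

In a 1.3-fold lower number from compound 2 to compound 3 (0.13 log units; within the scatter) in this assay, the series gains its first measured change in one place, and that step lies within the scatter. On this aromatic carbon, para to a large group, replacing trifluoromethyl with fluoro therefore gives no readable change, even though the heavy atoms of the substituent fall from 4 to 1. The compounds shown offer no evidence that bears on this result.

Going by these compounds, whether an amine, a carboxylic acid or a longer alkyl chain on this carbon would move the number beyond the scatter remains open. Also open, on these data alone, is whether a change to the methoxy groups on the shared core would do so, since this single step tests only the styryl aromatic ring.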